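A few compounds are considered here, and "the series" means these few. Any claim that something is new, unique, unknown or untested is made for them only; others in the source may bear on it.

Measured in a functional assay on MT4 cells (Homo sapiens) for cytotoxicity; on this read-out lower numbers stand for stronger inhibition and higher numbers for weaker inhibition:
- compound 1 `COc1cccc(Sc2cccc(N)c2C#N)c1`: > 200000 nM
- compound 2 `N#Cc1c(N)cccc1Sc1cccc(Br)c1`: 53000 nM
- compound 3 `N#Cc1cccc(Sc2cccc(N)c2C#N)c1`: 80000 nM

In this assay, compound 1 gives > 200000 nM, which is a limit of the assay and not a number. Going by the values given here, it is the only one of the three compounds reported this way, as the limit of > 200000 nM in this assay, at which 1 of the 3 values shown sits, records. The other two compounds both gave numbers, and the gap between them, a 1.5-fold higher number from compound 2 to compound 3 (0.18 log units; within the scatter), lies within the scatter.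

Compound 4 `COc1cc(Sc2cccc(N)c2C#N)cc(C(F)(F)F)c1` keeps the methoxy group of compound 1 and adds a new group to the same ring: trifluoromethyl in place of hydrogen on an aromatic carbon. Among the compounds with values here, no measured step makes this kind of addition, so the evidence is indirect. Replacing the methoxy group gave an at least 3.7-fold lower number from compound 1 to compound 2 (0.57 log units; beyond the scatter) with bromo and an at least 2.5-fold lower number from compound 1 to compound 3 (0.39 log units; beyond the scatter) with cyano. Both steps are beyond the scatter and both point to lower numbers, though each is only a bound.

By analogy with compound 2 at 53000 nM and compound 3 at 80000 nM, a modest move towards lower numbers is expected. A second limit remains possible. The expected step is an at least 3.3-fold lower number from compound 1 to compound 4 (0.52 log units; beyond the scatter). The estimated value for compound 4 is 60000 nM, with an expected range of 20000 nM to 200000 nM.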

Compound 4, half-maximal inhibitory concentration: 9000 nM
Beside the measured number, compound 4's estimate is 6.7-fold (0.82 log units) above it; measured number below the stated range.
By their numbers in this assay, from the lowest: compound 4; then compounds 2 and 3 (each within the scatter of the next). At a limit, above all of these: compound 1.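

In this assay, going by these compounds alone, the earlier steps only exchanged the methoxy group for another group, while this one keeps it and fills a hydrogen-bearing aromatic carbon, meta to a methoxy group, with trifluoromethyl: the result is an at least 22-fold lower number from compound 1 to compound 4 (1.34 log units; beyond the scatter). This shows that the position can take a new group and that the methoxy group need not leave for the number to fall, and the change is larger than either replacement step, as far as bounds can be set side by side. The size of the step is itself a bound and not an exact figure, as compound 1 stands at a limit and not at a number: the limit of > 200000 nM in this assay, at which 1 of the 4 values shown sits.

Going by these compounds, whether a chlorine atom, an amine or a carboxylic acid at this same position would move the number in the same way remains open, so the result cannot yet be tied to trifluoromethyl rather than to any added group. Also open, on these data alone, is whether trifluoromethyl would have the same effect with bromo or cyano in place of the methoxy group, or with the methoxy group absent.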